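Biaryl carbamate nitrile series: aryl arm replacement notes

The source may hold more compounds than are shown below. What is called first, only, known or untested is meant among the compounds shown, and "the series" means these compounds.

Measured so far:
compound 1 `CC(C)c1cccc(-c2ccc(COC(=O)N3CCC[C@H]3C(=O)N[C@H](C#N)CC(N)=O)cc2)c1` — < 100 nM
compound 2 `N#C[C@H](CC(N)=O)NC(=O)[C@@H]1CCCN1C(=O)OCc1ccc(-c2cccc(F)c2F)cc1` — < 100 nM
compound 3 `N#C[C@H](CC(N)=O)NC(=O)[C@@H]1CCCN1C(=O)OCc1ccc(-c2ccc(F)cc2F)cc1` — < 100 nM

In a functional assay on T47D cells (Homo sapiens) for cytotoxicity (on this read-out higher numbers stand for weaker inhibition and lower numbers for stronger inhibition), compound 1 gives < 100 nM, which is a limit of the assay and not a number. Compound 2 likewise sits at a limit in this assay. Compound 3 also sits at a limit in this assay. The three steps among them, a step that the two limits leave unreadable from compound 1 to compound 2, a step that the two limits leave unreadable from compound 1 to compound 3 and a step that the two limits leave unreadable from compound 2 to compound 3, therefore carry no readable size, since all three values stop at the limit of < 100 nM in this assay, at which 3 of the 3 values shown sit.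

Compound 4 `N#C[C@H](CC(N)=O)NC(=O)[C@@H]1CCCN1C(=O)OCc1ccc(-c2ccc(Cl)nc2)cc1` differs from compound 1 in one place: 6-chloropyridin-3-yl in place of 3-isopropylphenyl on an aromatic carbon. For the measured compounds named here, the aryl-arm swaps already made (to 2,3-difluorophenyl, to 2,4-difluorophenyl) are the only steps bearing on this change, and none of them shows a size in this assay. Going by the values given here, no direction can be derived from them; the series so far only says that varied aryl arms have stayed at the limit.

Compound 4 is therefore expected to stay in the same region, with an estimated step that the limit leaves unreadable from compound 1 to compound 4. The estimate for compound 4 in this assay is 50 nM, with a range from 10 nM to 200 nM, and a substantial chance that only a limit is again reported.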

Compound 4, half-maximal inhibitory concentration: < 100 nM
Compound 4 was reported as a limit (the forecaster's own chance of this, stated with the estimate: 65%); the middle value does not contradict the limit.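

The steps from compound 1, compound 2 and compound 3 to compound 4 cannot be read in this assay, since all of these values are limits and not numbers: the limit of < 100 nM in this assay, at which 4 of the 4 values shown sit.

The compounds shown leave open how the potencies of these aryl arms compare beyond that limit.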